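A few compounds are considered here, and "the series" means these few. Any claim that something is new, unique, unknown or untested is made for them only; others in the source may bear on it.

Compound 1 `COc1cccc(S(=O)(=O)c2cccc(N)c2C#N)c1`. In a functional assay on MT4 cells (Homo sapiens) for cytotoxicity (a lower number here means a stronger inhibitor, a higher number a weaker inhibitor), compound 1 gives > 200000 nM, which is a limit of the assay and not a number.
Compound 2 `Cc1cccc(S(=O)(=O)c2cccc(N)c2C#N)c1`. In this assay compound 2 gives 179000 nM.
Compound 3 `Cc1cc(C)cc(S(=O)(=O)c2cccc(F)c2C#N)c1`. In this assay compound 3 gives > 200000 nM, again a limit of the assay.

Among the measured compounds shown here, the one measured step is methoxy in place of methyl on an aromatic carbon, giving an at least 1.1-fold higher number from compound 2 to compound 1 (0.04 log units; that floor lies within the scatter). Two of the three values sit at the limit of > 200000 nM in this assay, at which 2 of the 3 values shown sit. The difference between the core of compound 2 and the core of compound 3 is not broken down here.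

Compound 4 `COc1cc(C)cc(S(=O)(=O)c2cccc(F)c2C#N)c1` differs from compound 3 by methoxy in place of methyl on an aromatic carbon. The place is the same kind as in the measured pair, but here it is also meta to a methyl group (1 heavy atom), so the change is of the same kind, not the same.

Compound 3 stands at a limit, and the measured step of an at least 1.1-fold higher number from compound 2 to compound 1 (0.04 log units; that floor lies within the scatter) lies within the scatter, so compound 4 is expected to remain at or near the limit. For compound 4 the estimate in this assay is 250000 nM, with an expected range of 120000 nM to 800000 nM. This estimate means an expected step that the limit leaves unreadable from compound 3 to compound 4.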

Compound 4, half-maximal inhibitory concentration: 8000 nM
For compound 4 the middle estimate is 31-fold (1.49 log units) above the measured one; measured number outside the range, below it.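

Methoxy in place of methyl on an aromatic carbon does not carry over as one fixed step between these two cores in this assay: the same change on two cores in this assay, an at least 1.1-fold higher number (0.04 log units; that floor lies within the scatter) from compound 2 to compound 1 and an at least 25-fold lower number (1.39 log units; beyond the scatter) from compound 3 to compound 4, at least 27-fold (1.44 log units) apart, beyond the scatter of two such steps.

On the core of compound 3 the change gives an at least 25-fold lower number from compound 3 to compound 4 (1.39 log units; beyond the scatter), which is a floor and not a full size, since compound 3 stands at a limit of the assay: the limit of > 200000 nM in this assay, at which 2 of the 4 values shown sit.

The two pairs do not show which difference between the cores goes with the gap, and they set no rule for the wider series.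

Open, on these data alone, is whether ethoxy or a longer chain in the same place on the core of compound 3 would give a step like that of methoxy. Also open, as far as these compounds go, is how a chlorine in place of the methyl group meta to the change would affect the step.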